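The source may report more compounds than this note shows. Statements on the series, on what has been measured and on what is new or still open speak of the compounds shown alone.

Two compounds have been measured in a functional assay on MCF7 cells (Homo sapiens) for antiproliferative activity, read by sulforhodamine B assay, with a stated time of 72 h (on this read-out higher numbers stand for weaker inhibition and lower numbers for stronger inhibition), so far
Compound 1 `O=C1CS/C(=N/Nc2nncc3ccccc23)N1c1ccccc1`: 77 nM
Compound 2 `C(=C/c1ccccc1)\C(=N\Nc1nncc2ccccc12)c1ccccc1`: 2.2 nM

Of these two, compound 2 has the lower number and so the stronger inhibition, and its gap to compound 1 lies beyond the scatter. The next compound to be tested is compound 3 `Clc1ccc(C(/C=C/c2ccccc2)=N\Nc2nncc3ccccc23)cc1`, which differs from compound 2 by one change: chloro in place of hydrogen on an aromatic carbon on the phenyl group, which thereby becomes 4-chlorophenyl. The chloro takes the place of a hydrogen on an aromatic carbon, para to a large group.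

Within the data shown here, no measured pair here shows what such a change does in this assay, so the expectation rests on the size of the structural change alone. That change is small, and no step beyond the scatter is expected in either direction. The step expected, a 1.4-fold higher number from compound 2 to compound 3 (0.13 log units; within the scatter), is accordingly modest, though the uncertainty is wide with so few data. For compound 3 the expected value is 3 nM, with an estimated range from 0.8 nM to 12 nM in this read-out.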

Compound 3, half-maximal inhibitory concentration: 3.6 nM
Beside the measured number, compound 3's estimate is 1.2-fold (0.08 log units) below it; the range from low to high includes it.
By their numbers in this assay, from the lowest: compounds 2 and 3 (each within the scatter of the next); then compound 1.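

In this assay, chloro in place of hydrogen on an aromatic carbon, para to a large group, gives a 1.6-fold higher number from compound 2 to compound 3 (0.21 log units; within the scatter) and so leaves the two compounds indistinguishable on this read-out. Among these compounds, this is the first step that changes a single place, and it shows that, for this one substituent, the change from phenyl to 4-chlorophenyl brings no shift that can be separated from the usual variation between repeated measurements. Nothing available here offers an explanation for this result, and no measurement of any property of the compounds bears on it.

The compounds shown leave open whether this position is as undemanding for other groups, since a single chloro cannot show how a methoxy group, an amine, a carboxylic acid or a longer chain would fare in the same place. They also leave open whether chloro would give a similar result on the other phenyl group of compound 2, or at another carbon of the same ring.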